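Swapping a methyl for a chlorine on the distal ring

This account rests on a few compounds, and the source may have more. Where it says the series, first, only, none or still open, it means among the compounds named here.

Measured compounds:
compound 1, `CN1CCN(c2ccc(NCc3ccccc3O)cc2)CC1` — "not active" (no number reported)
compound 2, `Cc1ccc(-c2ccc(NCc3ccccc3O)cc2)cc1` — 3790 nM

Two compounds were tested in a functional assay on Jurkat cells (Homo sapiens) for activation, with a stated time of 24 h; on this read-out higher numbers stand for an effect only at larger amounts of compound and lower numbers for an effect already at smaller amounts. Compound 1 is reported only as "not active" (no number reported), with no number. Going by the values given here, compound 2 is therefore the only compound with a numerical value, and in this assay compound 2 gives 3790 nM; there is nothing else on the scale to place it against.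

Compound 3, `Oc1ccccc1CNc1ccc(-c2cccc(Cl)c2)cc1`, has not been measured. It differs from compound 2 in one place: 3-chlorophenyl in place of 4-methylphenyl on an aromatic carbon. Among the compounds with values here, no step between two measured compounds bears on this change, so the expectation rests on compound 2 alone. Because compound 2 gives 3790 nM, the estimate for compound 3 is a step of a 1.2-fold lower number from compound 2 to compound 3 (0.07 log units; within the scatter), which is expected to stay within the usual scatter rather than move clearly in either direction. Compound 3 is thus estimated at 3200 nM, with a range from 1000 nM to 10000 nM.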

Compound 3, half-maximal effective concentration: 6200 nM
For compound 3 the middle estimate is 1.9-fold (0.29 log units) below the measured one; the measured number falls inside the stated range.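

In this assay, going by these compounds alone, the first readable step at this position, a 1.6-fold higher number from compound 2 to compound 3 (0.21 log units; within the scatter), shows that 3-chlorophenyl and 4-methylphenyl cannot be told apart on this read-out. The two groups differ both in the substituent and in where it sits on the ring, and this single step does not separate those two differences. No accompanying evidence bears on this result.

The compounds shown leave open whether either ring substituent contributes to the activity at all, as the unsubstituted phenyl ring does not appear among them. They also leave open whether an amine, a nitrile or a carboxylic acid on this ring would give a number in the same range or one clearly apart from it.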